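Chain extension on the saturated side chain, compound 2 to compound 3

The source may hold more compounds than are shown below. What is called first, only, known or untested is meant among the compounds shown, and "the series" means these compounds.

Measured compounds in this assay:
compound 1, `CCCCCC(CCO)n1cnc2c(N(C)C)ncnc21` — in a functional assay on HCT-116 cells (Homo sapiens) for antiproliferative activity, read by MTT assay, with a stated time of 48 h (on this read-out lower numbers stand for stronger inhibition and higher numbers for weaker inhibition), compound 1 gives > 50000 nM, a limit of the assay, not a number.
compound 2, `CCCCCC(CCO)n1cnc2c(N)ncnc21` — in this assay compound 2 gives > 50000 nM, also a limit of the assay.

Among the measured compounds shown here, compound 2 therefore stands at the limit of this assay and no number is known for it; the only evidence on the numbers is the limit of > 50000 nM in this assay, at which 2 of the 2 values shown sit. For the measured compounds named here, the single measured step, a step that the two limits leave unreadable from compound 1 to compound 2, lies between two limits and its size cannot be read.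

Compound 3, `CCCCCCCCCC(CCO)n1cnc2c(N)ncnc21`, differs from compound 2 by butyl in place of hydrogen on a saturated chain carbon, six bonds along the chain from an aromatic nitrogen. Going by the values given here, no measured step touches the saturated chain, so nothing tells how long a chain changes the read-out, and the one step that exists concerns the aromatic substituent alone. The expectation for compound 3 can rest only on compound 2 sitting at the limit > 50000 nM: the most likely outcome is that compound 3 also returns a limit rather than a number. For compound 3 the value is estimated at 60000 nM, with a range from 15000 nM to 200000 nM. The expected step is thus a step that the limit leaves unreadable from compound 2 to compound 3, and an attempt at a number is offered only loosely.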

Compound 3, half-maximal inhibitory concentration: 10500 nM
Beside the measured number, compound 3's estimate is 5.7-fold (0.76 log units) above it, and the stated range ends above it.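

Among the compounds shown here, the saturated chain carbon, six bonds along the chain from an aromatic nitrogen, is the first place where a change can be read: in this assay, butyl in place of hydrogen there gives an at least 4.7-fold lower number from compound 2 to compound 3 (0.67 log units; beyond the scatter). The earlier step, dimethylamino to amino on an aromatic carbon, joins two limits and cannot be read, so it gave no sign that the read-out could move at all. Compound 3 is therefore the first compound with a number, though the limit still dominates the values shown: the limit of > 50000 nM in this assay, at which 2 of the 3 values shown sit.

For the compounds shown here, the single step leaves the shape of the chain-length trend open, since a chain longer than that of compound 3 or one of intermediate length could show whether the number keeps falling, levels off or turns back. Also open, as far as these compounds go, is whether dimethylamino in place of amino on an aromatic carbon has a readable effect when carried on the chain of compound 3, and how an amine or a carboxylic acid in place of the hydroxyl would read.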